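Nitro for methyl on the sulfonyl aryl across two cores

The source may report more compounds than this note shows. Statements on the series, on what has been measured and on what is new or still open speak of the compounds shown alone.

Compound 1 `Cc1ccc(S(=O)(=O)N2C/C(=C\c3ccncc3)C(=O)/C(=C/c3ccccc3F)C2)cc1` gives 9700 nM in a functional assay on HepG2 cells (Homo sapiens) for cytotoxicity, read by MTT assay, with a stated time of 24 h; a lower number here means a stronger inhibitor, a higher number a weaker inhibitor. Compound 2 `O=C1/C(=C/c2ccncc2)CN(S(=O)(=O)c2ccc([N+](=O)[O-])cc2)C/C1=C\c1ccccc1F` differs by nitro in place of methyl on an aromatic carbon and gives 11300 nM, so the step of a 1.2-fold higher number from compound 1 to compound 2 (0.07 log units; within the scatter). Compound 3 `Cc1ccc(S(=O)(=O)N2C/C(=C\c3cccnc3)C(=O)/C(=C/c3ccccc3C(F)(F)F)C2)cc1` sits on a different core; how the two cores differ is not broken down here. In this assay compound 3 gives 2930 nM, the lowest number of the three measured. Compound 4 `O=C1/C(=C/c2cccnc2)CN(S(=O)(=O)c2ccc([N+](=O)[O-])cc2)C/C1=C\c1ccccc1C(F)(F)F` differs from compound 3 by nitro in place of methyl on an aromatic carbon, the same change as between compound 1 and compound 2, at the same place. Within the data shown here, the expected step is small, a 1.2-fold higher number from compound 3 to compound 4 (0.08 log units; within the scatter), because the one measured instance, a 1.2-fold higher number from compound 1 to compound 2 (0.07 log units; within the scatter), stayed within the scatter. Compound 4 is therefore estimated at 3500 nM in this assay, expected between 1700 nM and 7500 nM.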

Compound 4, half-maximal inhibitory concentration: 9370 nM
Estimate against measurement, compound 4: 2.7-fold (0.43 log units) below; measured number outside the range, above it.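

In this assay, the step from 4-methylphenyl to 4-nitrophenyl on the second core is a 3.2-fold higher number from compound 3 to compound 4 (0.50 log units; beyond the scatter), so this change cannot be treated as neutral on every core in the series. Its size depends on the core carrying it: the same change on two cores in this assay, a 1.2-fold higher number (0.07 log units; within the scatter) from compound 1 to compound 2 and a 3.2-fold higher number (0.50 log units; beyond the scatter) from compound 3 to compound 4, 2.7-fold (0.44 log units) apart, beyond the scatter of two such steps

Which difference between the two cores accounts for this gap remains unresolved, and two pairs set no rule for any further core.

Open, as far as these compounds go, is how an amine or a carboxylic acid would behave in place of methyl at the same place. Also open, from the compounds shown here alone, is the size of the step on a core carrying only one of the differences between these two cores.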